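The source may hold more compounds than are shown below. What is called first, only, known or untested is meant among the compounds shown, and "the series" means these compounds.

Measured compounds:
- Compound 1, `COC(=O)c1cccc(-c2cnc(C(O)CCc3ccc(-c4ccccc4)cc3)o2)n1`: 9000 nM
- Compound 2, `COC(=O)c1ccc(-c2cnc(C(=O)CCc3ccc(COc4ccccc4)cc3)o2)nc1`: 3.5 nM
- Compound 3, `CSc1cnc(C(=O)CCc2ccc(-c3ccccc3)cc2)o1`: 3 nM

In an assay for inhibition of Fatty-acid amide hydrolase 1 (Rattus norvegicus) (on this read-out lower numbers stand for stronger inhibition and higher numbers for weaker inhibition), compound 1 gives 9000 nM, the highest of the three numbers and therefore the weakest inhibition in the set. Compound 2 gives 3.5 nM and compound 3 gives 3 nM in this assay; both lie far below compound 1, beyond the usual scatter, while the two of them sit within scatter of each other and so cannot be ordered.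

The unmeasured compound 4, `O=C(O)c1cccc(-c2cnc(C(O)CCc3ccc(-c4ccccc4)cc3)o2)n1`, differs from compound 1 in one place: hydrogen in place of methyl on an oxygen next to a carbonyl group. This turns the methoxycarbonyl group into a carboxy group, the 6-(methoxycarbonyl)pyridin-2-yl into 6-carboxypyridin-2-yl. Among the measured compounds shown here, no measured pair in the set shows this change, so the direction of its effect cannot be read from the data.

For compound 4 the step in this assay is expected to be a 1.7-fold higher number from compound 1 to compound 4 (0.22 log units; within the scatter), a modest move toward weaker inhibition that may not exceed the scatter. Compound 4 is accordingly estimated at 15000 nM, within a range from 3000 nM to 60000 nM.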

Compound 4, inhibition constant: 1100 nM
Compound 4: middle estimate off by 14-fold (1.13 log units), on the high side; measured number outside the range, below it.
By their numbers in this assay, from the lowest: compounds 3 and 2 (each within the scatter of the next); then compound 4; then compound 1.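

Among the compounds shown here, the change from methoxycarbonyl to carboxy, with hydrogen in place of methyl on an oxygen next to a carbonyl group, gives an 8.2-fold lower number from compound 1 to compound 4 (0.91 log units; beyond the scatter) in this assay and is the first step in the set that can be read at this position. It shows that, on the core of compound 1, the free carboxy group moves the read-out toward stronger inhibition rather than weaker. Nothing measured here accounts for the shift.

The compounds shown leave open whether an amide, an ethyl ester or a hydroxymethyl group at this position would fall nearer to compound 1 or to compound 4. They also leave open whether the same change gives a step of similar size on a core that carries a ketone in place of the alcohol.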